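Phenyl to thiophen-2-yl: expectation for compound 4

The compounds below may be only part of what the source reports. "The series", "measured", "known", "first", "only" and "open" are said of these compounds alone.

Within the data shown here, compound 3 `CC(=O)OC[C@H]1O[C@@H](n2cc(CN3C(=O)/C(=C/c4ccccc4)c4ccccc43)nn2)[C@H](OC(C)=O)[C@@H](OC(C)=O)[C@@H]1OC(C)=O` gives 30200 nM in a functional assay on MCF7 cells (Homo sapiens) for cytotoxicity, read by sulforhodamine B assay, with a stated time of 48 h (a higher number here means a weaker inhibitor, a lower number a stronger inhibitor), the largest of the three numbers measured so far, although both other compounds lie within the scatter of it: compound 2 `CC(=O)OC[C@H]1O[C@@H](n2cc(CN3C(=O)/C(=C\c4ccccc4)c4ccccc43)nn2)[C@H](OC(C)=O)[C@@H](OC(C)=O)[C@@H]1OC(C)=O` gives 24300 nM and compound 1 `CC(=O)OC[C@H]1O[C@@H](n2cc(Cn3cc(/C=C4/C(=O)Nc5ccccc54)c4ccccc43)nn2)[C@H](OC(C)=O)[C@@H](OC(C)=O)[C@@H]1OC(C)=O` gives 22200 nM. Among the measured compounds shown here, the only measured single-point step, a 1.2-fold higher number from compound 2 to compound 3 (0.09 log units; within the scatter), rests on the fact that compounds 2 and 3 differ only in the configuration as drawn and stays within the scatter. Compound 4 `CC(=O)OC[C@H]1O[C@@H](n2cc(CN3C(=O)/C(=C/c4cccs4)c4ccccc43)nn2)[C@H](OC(C)=O)[C@@H](OC(C)=O)[C@@H]1OC(C)=O` differs from compound 3 by thiophen-2-yl in place of phenyl on a double-bonded chain carbon bound to a double-bonded ring carbon. For the measured compounds named here, no measured step touches this ring exchange, and the one step on record is too small to set a direction, so no change beyond the scatter is expected. The expected step is a 1.0-fold lower number from compound 3 to compound 4 (0.00 log units; within the scatter). Compound 4 is therefore estimated at 30000 nM, with a range from 12000 nM to 75000 nM.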

Compound 4, half-maximal inhibitory concentration: 28100 nM
The estimate for compound 4 lay 1.1-fold (0.03 log units) above the measured number, within the range that was stated.
By their numbers in this assay, from the lowest: compounds 1, 2, 4 and 3 (each within the scatter of the next).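

In this assay, thiophen-2-yl in place of phenyl on a double-bonded chain carbon bound to a double-bonded ring carbon gives a 1.1-fold lower number from compound 3 to compound 4 (0.03 log units; within the scatter), so this position now has a measured ring exchange, and it produces no change beyond the scatter. The exchange adds a sulfur atom and one hydrogen-bond acceptor without moving the number outside that scatter. Nothing on record accounts for this result.

From the compounds shown here alone, whether an amine, a carboxylic acid or a longer chain at this position would move the number beyond the scatter remains open. Also open, going by these compounds, is how thiophen-2-yl reads with the double bond drawn Z.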